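The source may report more compounds than this note shows. Statements on the series, on what has been measured and on what is new or still open speak of the compounds shown alone.

Working notes on the series. Of the compounds shown here, three have been measured in a functional assay on PC-3 cells (Homo sapiens) for inhibition; a higher number here means a weaker inhibitor, a lower number a stronger inhibitor. Compound 1 `c1ccc(Nc2cccc(-c3nc4ccccc4s3)c2)nc1` gives 4800 nM. Compound 2 `CCn1c(=O)/c(=C2\Sc3ccccc3N2C)s/c1=C\c1ccncc1Nc1cc(C)ccc1C` gives 2000 nM. Compound 3 `CCn1c(=O)/c(=C2\Sc3ccc(C)cc3N2C)s/c1=C\c1ccncc1Nc1ccccc1Cl` gives 500 nM, the lowest of the three numbers, beyond the scatter from both compound 2 and compound 1. Compound 4 `CCn1c(=O)/c(=C2\Sc3ccc(OC)cc3N2C)s/c1=C\c1ccncc1Nc1ccccc1Cl` has not yet been measured in this assay. It differs from compound 3 in one place: methoxy in place of methyl on an aromatic carbon. Within the data shown here, no measured pair shows this change, so its size cannot be read from the data. The expectation is a step from compound 3 to compound 4 of a 1.1-fold higher number from compound 3 to compound 4 (0.04 log units; within the scatter), in no firm direction and not beyond the scatter. Compound 4 is therefore estimated at 550 nM in this assay, within a range from 200 nM to 1600 nM.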

Compound 4, half-maximal inhibitory concentration: 760 nM
For compound 4 the middle estimate is 1.4-fold (0.14 log units) below the measured one; the measured number falls inside the stated range.
By their numbers in this assay, from the lowest: compounds 3 and 4 (each within the scatter of the next); then compound 2; then compound 1.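

In this assay, among these compounds, the first measured pair at this aromatic carbon gives a 1.5-fold higher number from compound 3 to compound 4 (0.18 log units; within the scatter) for methoxy in place of methyl. The added oxygen and hydrogen-bond acceptor therefore do not separate the two compounds at this position, so the position accepts either group in this assay. No available measurement bears on why the two groups read alike here. Open, on these data alone, is whether an amine, a carboxylic acid or a longer alkoxy chain on this carbon would also read alike. Also open, as far as these compounds go, is whether a bare hydrogen there would move the number beyond the scatter.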